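Shrinking the amide ring: from compound 2 to compound 3

The compounds below may be only part of what the source reports. "The series", "measured", "known", "first", "only" and "open" are said of these compounds alone.

Compound 1 `CC(C(=O)N1C[C@H]2CCC[C@H]2C1)N1CCN(S(=O)(=O)c2ccc(C(C)(C)C)cc2)CC1`: > 40000 nM
Compound 2 `CC(C(=O)N1CCCc2ccccc21)N1CCN(S(=O)(=O)c2ccc(C(C)(C)C)cc2)CC1`: > 40000 nM

In an ADME assay on HepG2 cells (Homo sapiens) for inhibition, with a stated time of 48 h (a higher number here means that more compound is needed for the effect, a lower number that less compound is needed), compound 1 gives only a limit, > 40000 nM. In this assay compound 2 also gives only a limit, > 40000 nM. Both values therefore sit at the same boundary (the limit of > 40000 nM in this assay, at which 2 of the 2 values shown sit), and compound 2 stands there with nothing resolved beyond it. For the measured compounds named here, the single measured step that the two limits leave unreadable from compound 1 to compound 2 changes the group on the carbonyl carbon, but its size cannot be read.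

Compound 3 `CC(C(=O)N1CCc2ccccc21)N1CCN(S(=O)(=O)c2ccc(C(C)(C)C)cc2)CC1` differs from compound 2 by 2,3-dihydro-1H-indol-1-yl in place of 1,2,3,4-tetrahydroquinolin-1-yl on a carbonyl carbon. Going by the values given here, only the unreadable step from compound 1 to compound 2 bears on this change, so no step of readable size in this assay can be expected from it. Compound 3 is estimated to give 40000 nM, with a range from 15000 nM to 100000 nM. The step from compound 2 to compound 3 is expected to be a number no higher from compound 2 to compound 3 (the limit leaves the size open), most likely again reported only as a limit.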

Compound 3, half-maximal effective concentration: > 40000 nM
Compound 3 gave a limit, no number (the forecaster's own chance of this, stated with the estimate: 75%); the middle value lies on the limit itself.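

In this assay compound 3 gives only a limit, > 40000 nM, so the steps to it from compound 1 and compound 2 cannot be read: the limit of > 40000 nM in this assay, at which 3 of the 3 values shown sit. The compounds shown leave open whether any of these groups on the carbonyl carbon changes the value at all.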